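Series notes: aryl substituent change on the isoxazole-bearing analogue

The source may report more compounds than this note shows. Statements on the series, on what has been measured and on what is new or still open speak of the compounds shown alone.

Three compounds share a nucleoside-like core and differ in the group hanging from the heteroaryl ring. In a functional assay on ACHN cells (Homo sapiens) for cytotoxicity, read by sulforhodamine B assay, tested at 10 uM (on this read-out higher numbers stand for more inhibition at the one concentration tested (going by the name of the read-out) and lower numbers for less inhibition), compound 1 `CCCc1cc(-c2cn([C@H]3C[C@H](OC(C)=O)[C@@H](COC(C)=O)O3)c(=O)[nH]c2=O)on1` gives 99.5%, compound 2 `CC(=O)OC[C@H]1O[C@@H](n2cc(-c3cn(Cc4ccc(C(C)C)cc4)nn3)c(=O)[nH]c2=O)C[C@@H]1OC(C)=O` gives 92.2%, and compound 3 `CC(=O)OC[C@H]1O[C@@H](n2cc(-c3cc(-c4ccc(C(C)(C)C)cc4)no3)c(=O)[nH]c2=O)C[C@@H]1OC(C)=O` gives 74.7%. Compound 3 is the lowest of the three in this assay, beyond the scatter against both others. Among the compounds with values here, the one directly comparable step, a number 24.8 percentage points lower from compound 1 to compound 3 (beyond the scatter), came with exchange of the small chain for the bulky aryl group.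

Compound 4 `CCc1ccc(-c2cc(-c3cn([C@H]4C[C@H](OC(C)=O)[C@@H](COC(C)=O)O4)c(=O)[nH]c3=O)on2)cc1` is the next analogue, not yet measured. The change ethyl in place of tert-butyl on an aromatic carbon keeps the aryl ring in place and only trims the substituent. Within the data shown here, no measured pair isolates this kind of change, so the expectation leans on the fact that compound 3 sits well below compound 1 and the new analogue moves part of the way back toward a smaller group. A small upward step of a number 7.3 percentage points higher from compound 3 to compound 4 (within the scatter) is therefore expected, not clearly beyond the scatter. For compound 4 the estimated value is 82%, in a range from 68% to 94%.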

Compound 4, a percentage reported as inhibition, at one concentration (the size of the read-out at that concentration, not a potency): 92%
Compound 4: the middle estimate sits 10 percentage points below what was measured; measured number inside the range.
By their numbers in this assay, from the lowest: compound 3; then compounds 4, 2 and 1 (each within the scatter of the next).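

In this assay, ethyl in place of tert-butyl on the aromatic carbon gives a number 17.3 percentage points higher from compound 3 to compound 4 (beyond the scatter), so the outcome at this position depends on the substituent even with the aryl ring kept. The aryl ring alone therefore does not account for the earlier fall: 4-ethylphenyl in place of propyl gives a number 7.5 percentage points lower from compound 1 to compound 4 (within the scatter), which ties the loss in compound 3 to the tert-butyl group rather than to the ring that carries it. Nothing available here explains the difference between the ethyl and tert-butyl groups.

As far as these compounds go, only these two substituents can be compared on this ring, so it remains open whether the response follows a graded trend through methyl, isopropyl or a longer chain. From the compounds shown here alone, the effect of an amine or a carboxylic acid at this carbon also remains open.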